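This account rests on a few compounds, and the source may have more. Where it says the series, first, only, none or still open, it means among the compounds named here.

In an ADME assay on HepG2 2.2.15 cells (Homo sapiens) for cytotoxicity, read by MTT assay, with a stated time of 8 days (on this read-out higher numbers stand for lower toxicity in this test and lower numbers for higher toxicity in this test), three compounds have been measured so far:

- Compound 1 `CC(=O)Nc1ccc(-c2nn(Cc3ccc(C#N)cc3)c(=O)c3ccccc23)c(F)n1` gives > 100000 nM as a limit of the assay
- Compound 2 `COCCNc1ccc(-c2nn(Cc3ccc(C#N)cc3)c(=O)c3ccccc23)c(F)n1` gives > 100000 nM as a limit of the assay
- Compound 3 `CN(C)c1ccc(-c2nn(Cc3ccc(C#N)cc3)c(=O)c3ccccc23)c(F)n1` gives 79200 nM as a true number

Going by the values given here, compound 3 carries the only true number of the three. Compound 1 and compound 2 stand at the limit of > 100000 nM in this assay, at which 2 of the 3 values shown sit, and no number can be given for them.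

Compound 4 `N#Cc1ccc(Cn2nc(-c3ccc(N)nc3F)c3ccccc3c2=O)cc1` comes from compound 3 by one change, amino in place of dimethylamino on an aromatic carbon. It has not yet been measured.

Two measured steps end at the dimethylamino group of compound 3 and so bear on this change. They are an at least 1.2-fold lower number from compound 1 to compound 3 (0.10 log units; that floor lies within the scatter) and an at least 1.2-fold lower number from compound 2 to compound 3 (0.10 log units; that floor lies within the scatter) and the limits hide how large either really is. Neither gives grounds for a large move, so no step beyond the scatter is expected in this assay for the new amino group. The step expected is a 1.1-fold higher number from compound 3 to compound 4 (0.06 log units; within the scatter) and the assay may well report only its limit. For compound 4 the expected value is 90000 nM within an estimated range of 45000 nM to 180000 nM on this read-out.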

Compound 4, half-maximal cytotoxic concentration: > 100000 nM
Compound 4 was reported as a limit; the forecaster's own chance of this, stated with the estimate: 55%; middle value at least 1.1-fold (0.04 log units) from the limit.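

Amino in place of dimethylamino on this aromatic carbon gives an at least 1.2-fold higher number from compound 3 to compound 4 (0.10 log units; that floor lies within the scatter) in this assay, so even the group with the fewest heavy atoms shown here does not bring the read-out under the limit. The earlier compounds shown here showed only substituted nitrogens at this position, and compound 4 shows that the plain amino group also ends at the limit, which leaves the dimethylamino group of compound 3 as the only one here with a true number. The steps to compound 4 from compound 1 and from compound 2 cannot be read, and these three compounds cannot be put in any order because they share one ceiling: the limit of > 100000 nM in this assay, at which 3 of the 4 values shown sit.

The compounds shown leave open whether any group at this position gives a step beyond the scatter, and how far the three compounds at the limit really lie from compound 3. As far as these compounds go, it also stays open how a cyclic amine such as morpholine or a longer alkyl chain on the nitrogen would read in this test, and whether the fluoro group plays any part.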